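A few compounds are considered here, and "the series" means these few. Any claim that something is new, unique, unknown or untested is made for them only; others in the source may bear on it.

Measured in a functional assay on Jurkat cells (Homo sapiens); a lower number here means a stronger inhibitor, a higher number a weaker inhibitor:
compound 1 `C[C@H](NC(=O)C(=O)NCC1(c2ccccc2)CC1)C(=O)N[C@@H](CC(=O)O)C(=O)COc1c(F)c(F)cc(F)c1F`: 27 nM
compound 2 `Cc1ccc(C)c(CNC(=O)C(=O)N[C@@H](C)C(=O)N[C@@H](CC(=O)O)C(=O)COc2c(F)c(F)cc(F)c2F)c1`: 11 nM

Of these two, compound 2 has the lower number, with a 2.5-fold lower number from compound 1 to compound 2 (0.39 log units; beyond the scatter). Compound 3 `C[C@H](NC(=O)C(=O)NCc1cc(Cl)cc(Cl)c1)C(=O)N[C@@H](CC(=O)O)C(=O)COc1c(F)c(F)cc(F)c1F` is still unmeasured and differs from compound 2 as follows: 3,5-dichlorophenyl in place of 2,5-dimethylphenyl on a saturated chain carbon bound to an amide-type nitrogen. Going by the values given here, only one measured step bears on this change, the modest one at the same place, on a saturated chain carbon bound to an amide-type nitrogen. Among the compounds with values here, no measured compound carries 3,5-dichlorophenyl, so the direction remains open, and a step of similar or smaller size is expected in this assay, leaning slightly toward a higher number. The expected step is a 1.3-fold higher number from compound 2 to compound 3 (0.10 log units; within the scatter). For compound 3 the estimate is 14 nM, with an expected range from 5 nM to 40 nM.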

Compound 3, half-maximal inhibitory concentration: 23 nM
The estimate for compound 3 lay 1.6-fold (0.22 log units) below the measured number, and the stated range covers the measured number.
By their numbers in this assay, from the lowest: compound 2; then compounds 3 and 1 (each within the scatter of the next).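

With a 2.1-fold higher number from compound 2 to compound 3 (0.32 log units; beyond the scatter) the change to 3,5-dichlorophenyl shows that the advantage of compound 2 at this position does not extend to every substituted phenyl, even at the same heavy-atom count and with the same aromatic ring. With a 1.2-fold lower number from compound 1 to compound 3 (0.07 log units; within the scatter) the 3,5-dichlorophenyl group stands level with the 1-phenylcyclopropyl group. No measurement available here accounts for these differences.

The compounds shown leave open whether the methyl groups themselves or their placement on the ring carry the advantage of compound 2. They also leave open how a methoxy group or an amine on that phenyl ring would fare.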